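A few compounds are considered here, and "the series" means these few. Any claim that something is new, unique, unknown or untested is made for them only; others in the source may bear on it.

Both compounds in this series show weak growth inhibition in a functional assay on HepG2 cells (Homo sapiens) for inhibition, read by MTT assay, with a stated time of 72 h, tested at 50 uM; a lower number here means less inhibition of growth, a higher number more inhibition of growth at the concentration tested. Compound 1 `C=CCc1ccc(OCc2cn(-c3ccccc3CO)nn2)c(O)c1` gives 8.5% in this assay. Compound 2 `C=CCc1cc(O)c(O)c(CN2CCC(CO)CC2)c1`, which shares the allyl-substituted phenol but carries a different side chain, gives 5.4% in this assay. The two numbers lie within the scatter of each other, so neither compound can be set apart from the other on the values at hand; compound 1 simply sits alongside compound 2 at a low level of inhibition.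

Compound 3 `C=CCc1ccc(OCc2cn(-c3ccccc3Cl)nn2)c(O)c1` has not yet been measured. It differs from compound 1 in a single place: chloro in place of hydroxymethyl on an aromatic carbon. Going by the values given here, no step between measured compounds bears on this change, so nothing shows how the swap of hydroxymethyl for chloro at this position moves the read-out. Given that compound 1 gives 8.5% and the shared core gives similar numbers in compound 2, the step from compound 1 to compound 3 is expected to stay small, a number 1.5 percentage points higher from compound 1 to compound 3 (within the scatter), with no direction favoured beyond the scatter. Compound 3 is accordingly estimated at 10%, within 0% to 25%.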

Compound 3, percent growth inhibition at one concentration: 4.7%
Estimate against measurement, compound 3: 5.3 percentage points above; the measured number falls inside the stated range.
By their numbers in this assay, from the lowest: compounds 3, 2 and 1 (each within the scatter of the next).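

Chloro in place of hydroxymethyl on an aromatic carbon, ortho to a large group, gives the first step that can be read at this position: in this assay, it is a number 3.8 percentage points lower from compound 1 to compound 3 (within the scatter). The exchange of 2-(hydroxymethyl)phenyl for 2-chlorophenyl removes the hydrogen-bond donor and acceptor counted for hydroxymethyl, yet the read-out does not separate the two compounds, so this pair gives no sign that either group matters for growth inhibition at the concentration tested. Nothing at hand accounts for this result or ties it to any property of either group.

The compounds shown leave open whether an aminomethyl group, a carboxylic acid or a longer alkyl chain at this place on the aromatic ring would move the read-out beyond the scatter, as only hydroxymethyl and chloro can be compared here. Going by these compounds alone, also open is the contribution of the side chain on the shared core, as compound 2 differs from compound 1 in more than one place and no step links the two.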